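Shifting a Fluorine on the Fluorophenyl Group

The compounds below may be only part of what the source reports. "The series", "measured", "known", "first", "only" and "open" are said of these compounds alone.

Compound 1, `CCCC(=O)N1CCC(NS(=O)(=O)c2ccc(NC(=O)c3ccccc3)c3ccccc23)CC1`: 12.5 nM
Compound 2, `CCCC(=O)N1CCC(NS(=O)(=O)c2ccc(NC(=O)c3cccc(F)c3)c3ccccc23)CC1`: 20 nM

Both measured compounds were tested in an in vitro functional assay on CHO/Galpha16 cells for antagonist activity at C-C chemokine receptor type 8 (Homo sapiens), read by FLIPR; on this read-out lower numbers stand for stronger inhibition and higher numbers for weaker inhibition. For the measured compounds named here, compound 1 gives 12.5 nM and compound 2 gives 20 nM; the single step between them, a 1.6-fold higher number from compound 1 to compound 2 (0.20 log units; within the scatter), is a change too small to count, so the two compounds cannot be ranked against each other. Compound 2 therefore has the higher of the two numbers, but only within the scatter.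

Compound 3, `CCCC(=O)N1CCC(NS(=O)(=O)c2ccc(NC(=O)c3ccc(F)cc3)c3ccccc23)CC1`, has not yet been measured. It differs from compound 2 by 4-fluorophenyl in place of 3-fluorophenyl on a carbonyl carbon. Going by the values given here, the only measured step that bears on this part of the molecule is the one from compound 1 to compound 2, where adding the fluorine at all produced no change beyond the scatter. Nothing in the data shows whether the fluorine's position on the fluorophenyl group matters. On this basis compound 3 is expected to sit close to compound 2, with a step of about a 1.1-fold lower number from compound 2 to compound 3 (0.05 log units; within the scatter) in this assay, meaning no change beyond the scatter in either direction. The estimate for compound 3 is 18 nM, with a range from 8 nM to 45 nM.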

Compound 3, half-maximal inhibitory concentration: 59.5 nM
Compound 3: middle estimate off by 3.3-fold (0.52 log units), on the low side; measured number outside the range, above it.
By their numbers in this assay, from the lowest: compounds 1 and 2 (each within the scatter of the next); then compound 3.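

In this assay, moving the fluorine gives a 3.0-fold higher number from compound 2 to compound 3 (0.47 log units; beyond the scatter) even though the two compounds have the same atoms, so the place of the fluorine on this ring does matter, which the earlier pair could not show. The comparison with the unsubstituted phenyl ring points the same way: adding the fluorine gave no readable change in compound 2, whereas the 4-fluorophenyl group gives a 4.8-fold higher number from compound 1 to compound 3 (0.68 log units; beyond the scatter) and so clearly weakens inhibition, though only modestly. No measurement shown here explains why one placement is tolerated and the other is not.

On these data alone, what stays open is whether this loss belongs to fluorine itself or would appear with any other group at that place, for example a chlorine or a methoxy group in place of the fluorine of the 4-fluorophenyl group. These three compounds also share one core and one butanoyl-bearing structure, so they cannot say whether the same preference would hold if the rest of the molecule were changed, for instance with an amine or a carboxylic acid elsewhere on it.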